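The source may hold more compounds than are shown below. What is called first, only, known or untested is meant among the compounds shown, and "the series" means these compounds.

Compound 1 `CC(C)(C)C(=O)Nc1ccc(-c2ccc(C(=O)N[C@H]3CN[C@@H](C(=O)Nc4ccc(Cl)c(C(F)(F)F)c4)C3)cc2)cn1` and compound 2 `CC(=O)Nc1ccc(-c2ccc(C(=O)N[C@H]3CN[C@@H](C(=O)Nc4ccc(Cl)c(C(F)(F)F)c4)C3)cc2)cn1` share one core, and compound 3 `CC(=O)Nc1ccc(-c2cccc(C(=O)N[C@@H](C)C(=O)Nc3ccc(Cl)c(C(F)(F)F)c3)c2)cn1` and compound 4 `C[C@H](NC(=O)c1cccc(-c2ccc(NC(=O)C(C)(C)C)nc2)c1)C(=O)Nc1ccc(Cl)c(C(F)(F)F)c1` share another; how the two cores differ is not broken down here. In a functional assay on K562 cells (Homo sapiens) for inhibition, read by MTT assay, with a stated time of 48 h (on this read-out higher numbers stand for weaker inhibition and lower numbers for stronger inhibition), compound 1 gives 11600 nM. In the same setting compound 2 gives 22800 nM, and compound 3 gives 42800 nM. Compound 1 is made from compound 2 by the change (tert-butyl in place of methyl on a carbonyl carbon), which gave a 2.0-fold lower number from compound 2 to compound 1 (0.29 log units; within the scatter). Compound 4 is made from compound 3 by the change (tert-butyl in place of methyl on a carbonyl carbon), a change of the same kind at the same kind of place, so this change is seen twice among these compounds, once measured and once not. Because the measured step of a 2.0-fold lower number from compound 2 to compound 1 (0.29 log units; within the scatter) stayed within the scatter, the expectation for compound 4 is a step of about the same size on the new core, giving a 1.7-fold lower number from compound 3 to compound 4 (0.23 log units; within the scatter), though a single earlier step on a different core is a thin basis. Compound 4 is therefore expected to show roughly 25000 nM in this assay. Given that thin basis, the value of compound 4 is estimated to fall between 10000 nM and 60000 nM.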

Compound 4, half-maximal inhibitory concentration: 18400 nM
Compound 4: middle estimate off by 1.4-fold (0.13 log units), on the high side, and the stated range covers the measured number.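

In this assay, putting tert-butyl in place of methyl on the carbonyl carbon gave a 2.3-fold lower number from compound 3 to compound 4 (0.37 log units; beyond the scatter), a modest step in the same direction as the one seen earlier on the core of compound 1. Set side by side, the two steps agree in size, so in this small set the change carried over from one core to the other with little difference: the same change on two cores in this assay, a 2.0-fold lower number (0.29 log units; within the scatter) from compound 2 to compound 1 and a 2.3-fold lower number (0.37 log units; beyond the scatter) from compound 3 to compound 4, 1.2-fold (0.07 log units) apart, within the scatter of two such steps This is still only two cores, and since the earlier step alone stayed within the scatter, the case rests on the agreement of the pair; it shows neither why the number falls nor that the same step would appear on a third core.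

Only the two ends of this swap are shown, methyl and tert-butyl, so it remains open how an ethyl or isopropyl group would fall on the same carbonyl carbon, or whether a chain ending in an amine or a carboxylic acid would follow the same direction. All the numbers also come from one cell read-out, which leaves open whether the step would hold in any other test.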